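The source may hold more compounds than are shown below. What is called first, only, known or untested is meant among the compounds shown, and "the series" means these compounds.

Among the measured compounds shown here, compound 2 `CC#CC(CC(=O)O)c1ccc(OCc2ccc(C(=O)N3CCN(c4cccnc4)CC3)s2)cc1` gives 1140 nM in a functional assay on HEK293 cells for agonist activity at Free fatty acid receptor 1 (Homo sapiens), read by fluorescence and calcium flux (on this read-out lower numbers stand for an effect already at smaller amounts and higher numbers for an effect only at larger amounts of compound), the highest of the two numbers so far. Compound 1 `CC#CC(CC(=O)O)c1ccc(OCc2ccc(C(=O)N3CCN(Cc4ccccc4)CC3)s2)cc1` gives 155 nM in this assay, and the step of a 7.4-fold higher number from compound 1 to compound 2 (0.87 log units; beyond the scatter) lies beyond the scatter. Compound 3 `CC#CC(CC(=O)O)c1ccc(OCc2ccc(C(=O)N3CCN(c4ccccn4)CC3)s2)cc1` differs from compound 2 by pyridin-2-yl in place of pyridin-3-yl on an amine nitrogen in a ring. For the measured compounds named here, no measured step compares pyridin-2-yl with pyridin-3-yl on this ring nitrogen, so the only known step, which swaps benzyl for a pyridinyl, does not bear directly on this change. For compound 3 the expected step is a 1.1-fold lower number from compound 2 to compound 3 (0.06 log units; within the scatter), nothing beyond the scatter. Compound 3 is therefore estimated at 1000 nM, with a range of 350 nM to 3000 nM.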

Compound 3, half-maximal effective concentration: 138 nM
The estimate for compound 3 lay 7.2-fold (0.86 log units) above the measured number; the whole stated range lies above it.
By their numbers in this assay, from the lowest: compounds 3 and 1 (each within the scatter of the next); then compound 2.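

On the ring nitrogen, the position of the nitrogen within the attached pyridine decides the outcome: pyridin-2-yl in place of pyridin-3-yl gives an 8.3-fold lower number from compound 2 to compound 3 (0.92 log units; beyond the scatter), although both groups have the same atoms and counts. Pyridin-2-yl in place of benzyl gives a 1.1-fold lower number from compound 1 to compound 3 (0.05 log units; within the scatter), so the rise seen with pyridin-3-yl does not hold for both pyridinyl groups. Nothing available accounts for the difference between these two pyridinyl groups.

Still open, as far as these compounds go, is where pyridin-4-yl or plain phenyl on this ring nitrogen would fall. Also open, from the compounds shown here alone, is whether pyrimidin-2-yl would stay level with compound 3.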